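Iodo Substitution on a Benzothiazolyl Aminomethyl Naphthol Series

The source may report more compounds than this note shows. Statements on the series, on what has been measured and on what is new or still open speak of the compounds shown alone.

Measured compounds: compound 1 `COc1ccc2nc(NC(c3cn(-c4ccccc4)nc3-c3cccc(I)c3)c3c(O)ccc4ccccc34)sc2c1` gives 6240 nM; compound 2 `COc1ccc2nc(NC(c3cn(-c4ccccc4)nc3-c3ccccc3)c3c(O)ccc4ccccc34)sc2c1` gives 8290 nM; compound 3 `Oc1ccc2ccccc2c1C(Nc1nc2ccc(Cl)cc2s1)c1cn(-c2ccccc2)nc1-c1ccccc1` gives 12500 nM, all in a functional assay on HeLa cells (Homo sapiens) for antiproliferative activity, read by MTT assay, with a stated time of 48 h; a lower number here means a stronger inhibitor, a higher number a weaker inhibitor.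

Compound 4 `Oc1ccc2ccccc2c1C(Nc1nc2ccc(Cl)cc2s1)c1cn(-c2ccccc2)nc1-c1ccc(I)cc1` has not been measured in this assay. It differs from compound 3 by iodo in place of hydrogen on an aromatic carbon. The same kind of change was made from compound 2 to compound 1, (iodo in place of hydrogen on an aromatic carbon), where the step in this assay was a 1.3-fold lower number from compound 2 to compound 1 (0.12 log units; within the scatter). The two changes are not the same: in compound 1 the iodo sits meta to a large group, in compound 4 para to a large group. The cores also differ, by chloro in place of methoxy on an aromatic carbon, with a 1.5-fold higher number from compound 2 to compound 3 (0.18 log units; within the scatter).

Since the earlier step was a 1.3-fold lower number from compound 2 to compound 1 (0.12 log units; within the scatter), compound 4 is expected to show a similar small step, a 1.3-fold lower number from compound 3 to compound 4 (0.10 log units; within the scatter). The estimate for compound 4 is 10000 nM, between 5000 nM and 20000 nM.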

Compound 4, half-maximal inhibitory concentration: 12100 nM
Estimate against measurement, compound 4: 1.2-fold (0.08 log units) below, within the range that was stated.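

In this assay, the change from phenyl to 4-iodophenyl gives a 1.0-fold lower number from compound 3 to compound 4 (0.01 log units; within the scatter). Set beside the earlier step on the other core, the two results agree: the same change on two cores in this assay, a 1.3-fold lower number (0.12 log units; within the scatter) from compound 2 to compound 1 and a 1.0-fold lower number (0.01 log units; within the scatter) from compound 3 to compound 4, 1.3-fold (0.11 log units) apart, within the scatter of two such steps. This shows that in these two pairs, iodo in place of hydrogen leaves the number within the scatter on either core, but two pairs are few, the iodo stands at a different place in each, and neither pair shows what the same change would do on any further core.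

The compounds shown leave open whether an amine, a carboxylic acid or a longer chain at this place on the aromatic ring would give a step beyond the scatter. They also leave open how iodo would behave in any other assay.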